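Clearance notes: aryl swap at the para position

The source may report more compounds than this note shows. Statements on the series, on what has been measured and on what is new or still open speak of the compounds shown alone.

Measured compounds:
compound 1 `COc1ccc(C(=O)C2=C(O)C(=O)N(c3ccc(-c4ccon4)cc3)C2C2CCCCC2)cn1` — 4.6 mL/min/kg
compound 2 `COc1ccc(C(=O)C2=C(O)C(=O)N(c3ccc(-c4ccon4)cc3)C2c2ccccc2OC)cc1` — 8.8 mL/min/kg
compound 3 `Cc1cc(-c2ccc(N3C(=O)C(O)=C(C(=O)C(C)(C)C)C3c3ccccc3OCCO)cc2)on1` — "not determined" (no result reported)

In an ADME assay on the whole organism (Rattus norvegicus) for pharmacokinetics (on this read-out lower numbers stand for slow clearance and higher numbers for fast clearance), compound 1 gives 4.6 mL/min/kg. In this assay compound 2 gives 8.8 mL/min/kg. Going by the values given here, these two values lie within the usual scatter of each other, so nothing so far separates slow from fast clearance. Compound 3 `Cc1cc(-c2ccc(N3C(=O)C(O)=C(C(=O)C(C)(C)C)C3c3ccccc3OCCO)cc2)on1` is reported as "not determined" (no result reported) in this assay; it stands on the series only through its structure, which shares the hydroxy-enone core of compound 1 and compound 2.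

Compound 4 `CC(C)(C)C(=O)C1=C(O)C(=O)N(c2ccc(-c3cccs3)cc2)C1c1ccccc1OCCO` is the next member. It differs from compound 3 in one place: thiophen-2-yl in place of 3-methyl-1,2-oxazol-5-yl on an aromatic carbon. Among the compounds with values here, no measured step covers this change, so its size and direction in this assay are unknown; a shift beyond the scatter in either direction cannot be ruled out, nor can a step within it.

Compound 4 is expected to give a clearance of about 8 mL/min/kg in this assay, with a range from 3 mL/min/kg to 22 mL/min/kg, resting on the values of compound 1 and compound 2.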

Compound 4, clearance: 1.3 mL/min/kg
Estimate against measurement, compound 4: 6.2-fold (0.79 log units) above; measured number below the stated range.
By their numbers in this assay, from the lowest: compound 4; then compounds 1 and 2 (each within the scatter of the next).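

In this assay compound 3 carries no number, so the step from it to compound 4 cannot be read. The compounds shown leave open how the swap of 3-methyl-1,2-oxazol-5-yl for thiophen-2-yl alone moves clearance. Nothing on hand bears on this result.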